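Anilinoquinazoline series: aniline replacement on compound 2

A few compounds are considered here, and "the series" means these few. Any claim that something is new, unique, unknown or untested is made for them only; others in the source may bear on it.

Compound 2 `COc1cc2ncnc(Nc3ccc(F)c(Br)c3)c2cc1OCCCCC(=O)Nc1ccc(S(N)(=O)=O)cc1` is, in a functional assay on NCI-H1975 cells (Homo sapiens) for antiproliferative activity, read by MTT assay, with a stated time of 72 h (on this read-out higher numbers stand for weaker inhibition and lower numbers for stronger inhibition), the lower of the two numbers recorded, with 31600 nM, but it stands within the scatter of compound 1 `COc1cc2ncnc(Nc3ccc(F)c(Cl)c3)c2cc1OCCCCC(=O)Nc1ccc(S(N)(=O)=O)cc1`, which gives 35600 nM. Going by the values given here, the only measured step, a 1.1-fold lower number from compound 1 to compound 2 (0.05 log units; within the scatter), does not reach beyond the scatter. Compound 3 `COc1ccccc1Nc1ncnc2cc(OC)c(OCCCCC(=O)Nc3ccc(S(N)(=O)=O)cc3)cc12` differs from compound 2 by 2-methoxyphenyl in place of 3-bromo-4-fluorophenyl on a nitrogen on an aromatic ring. Among the compounds with values here, no measured step bears on this change, so the expected step of a 1.3-fold higher number from compound 2 to compound 3 (0.10 log units; within the scatter) from compound 2 to compound 3 is uncertain in direction. Compound 3 is estimated at 40000 nM, with a range from 12000 nM to 130000 nM.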

Compound 3, half-maximal inhibitory concentration: 8030 nM
For compound 3 the middle estimate is 5.0-fold (0.70 log units) above the measured one; measured number outside the range, below it.
By their numbers in this assay, from the lowest: compound 3; then compounds 2 and 1 (each within the scatter of the next).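

In this assay, going by these compounds alone, changing the aryl group on the aniline nitrogen gives the first step beyond the scatter: a 3.9-fold lower number from compound 2 to compound 3 (0.59 log units; beyond the scatter), and a 4.4-fold lower number from compound 1 to compound 3 (0.65 log units; beyond the scatter). The chloro-to-bromo exchange left the number within the scatter, whereas the full replacement by 2-methoxyphenyl shows that this position can respond, though the gain is modest. Nothing at hand explains the step.

The compounds shown do not separate the gain from methoxy from the loss of both halogens. Unsubstituted phenyl, or a hydroxyl, ethoxy or amine in place of methoxy, remains open.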